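From benzyl to 5-methylpyrimidin-2-yl on an aromatic nitrogen

The source may hold more compounds than are shown below. What is called first, only, known or untested is meant among the compounds shown, and "the series" means these compounds.

Measured so far in a toxicity assay on HT-29 cells (Homo sapiens) for cytotoxicity; a higher number here means that more compound is tolerated, a lower number that less compound is tolerated
Compound 1 `CN1C(=S)[C@@H](NC(=O)c2nc(Cc3ccccc3)n(C)n2)COc2ccccc21` gives > 100000 nM
Compound 2 `CN1C(=S)[C@@H](NC(=O)c2nc(Cc3ccccc3)n(C3COC3)n2)COc2ccccc21` gives > 100000 nM
Compound 3 `CN1C(=S)[C@@H](NC(=O)c2nc(Cc3ccccc3)n(Cc3ccccc3)n2)COc2ccccc21` gives > 100000 nM

In this assay compound 3 reads > 100000 nM, and this is a limit, not a number. Compound 1 and compound 2 share that position, so all three sit at the limit of > 100000 nM in this assay, at which 3 of the 3 values shown sit, and cannot be ranked.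

Compound 4 `Cc1cnc(-n2nc(C(=O)N[C@H]3COc4ccccc4N(C)C3=S)nc2Cc2ccccc2)nc1` has 5-methylpyrimidin-2-yl in place of benzyl on an aromatic nitrogen of the five-membered aromatic ring with 3 nitrogen, and 5-methylpyrimidin-2-yl in place of benzyl on an aromatic nitrogen counts what changes.

Going by the values given here, three measured steps bear on this change. They are a step that the two limits leave unreadable from compound 1 to compound 2 and a step that the two limits leave unreadable from compound 1 to compound 3 and a step that the two limits leave unreadable from compound 2 to compound 3, so none offers a size to carry over. Still, methyl, oxetan-3-yl and benzyl on that nitrogen all leave their compounds at the same limit. The expectation therefore rests on compound 3 and its two neighbours sitting at the limit of > 100000 nM in this assay, at which 3 of the 3 values shown sit, and a lower reading cannot be excluded, since none of them gives a number.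

The estimated step is a number no higher from compound 3 to compound 4 (the limit leaves the size open), with no change beyond the usual scatter expected in this assay.

For compound 4 the expected value is 100000 nM, with an estimated range from 30000 nM to 100000 nM.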

Compound 4, half-maximal cytotoxic concentration: > 100000 nM
Compound 4 ended at the assay's limit (the forecaster's own chance of this, stated with the estimate: 80%); the middle value lies on the limit itself.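

In this assay compound 4 gives > 100000 nM as a limit of the assay, not a number. Going by these compounds alone, no step among compound 1, compound 2, compound 3 and compound 4 can be read, because all four share one position: the limit of > 100000 nM in this assay, at which 4 of the 4 values shown sit.

The compounds shown leave open how much of each compound the cells tolerate, and whether changing the group on that aromatic nitrogen alters this at all.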